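From a Free Amine to an Acetyl Benzyl Amide

The source may report more compounds than this note shows. Statements on the series, on what has been measured and on what is new or still open speak of the compounds shown alone.

Measured compounds:
compound 1, `CCCCc1ccc(CN(C(C)C)S(C)(=O)=O)c(=O)n1Cc1ccc(-c2ccccc2-c2nn[nH]n2)cc1`: 82.7%
compound 2, `CCCCc1ccc(CN)c(=O)n1Cc1ccc(-c2ccccc2-c2nn[nH]n2)cc1`: 2.8%

In a functional assay on the whole organism (artery) for inhibition, with Rattus norvegicus as the target, at a dose of 3 mg/kg by the intraduodenal route (on this read-out higher numbers stand for more inhibition at the one dose given (going by the name of the read-out) and lower numbers for less inhibition), compound 1 gives 82.7%. For the measured compounds named here, compound 2 gives 2.8%, the lowest of the two numbers, and the only step known, a number 79.9 percentage points lower from compound 1 to compound 2 (beyond the scatter), shows how far the unsubstituted amine falls behind the disubstituted nitrogen of compound 1.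

Compound 3, `CCCCc1ccc(CN(Cc2ccccc2)C(C)=O)c(=O)n1Cc1ccc(-c2ccccc2-c2nn[nH]n2)cc1`, returns to a nitrogen carrying two groups: acetyl(benzyl)amino in place of amino on a saturated chain carbon bound to an aromatic carbon. The step from compound 1 to compound 2 is the one that bears on this change, and it was large, so a large rise is expected in this assay when the free amine is again capped. How much of it is recovered by acetyl and benzyl rather than isopropyl and methylsulfonyl is not shown by any measured pair, so the range is wide. Compound 3 is therefore estimated at 55%, between 20% and 85%, which is expected to mean a step of a number 52.2 percentage points higher from compound 2 to compound 3 (beyond the scatter).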

Compound 3, a percentage reported as inhibition, in the whole organism at one dose (the size of the read-out at that dose, not a potency): 76.3%
The estimate for compound 3 lay 21.3 percentage points below the measured number, and the stated range covers the measured number.
By their numbers in this assay, from the lowest: compound 2; then compounds 3 and 1 (each within the scatter of the next).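

On the saturated chain carbon bound to an aromatic carbon, replacing amino with acetyl(benzyl)amino gives a number 73.5 percentage points higher from compound 2 to compound 3 (beyond the scatter) in this assay, so the high read-out is not confined to the isopropyl and methylsulfonyl pair on the nitrogen of compound 1. The exchange of isopropyl(methylsulfonyl)amino for acetyl(benzyl)amino reads a number 6.4 percentage points lower from compound 1 to compound 3 (within the scatter), which means that this assay does not separate these two differently substituted nitrogens. Nothing at hand accounts for these numbers.

The compounds shown leave open whether a single group on the nitrogen would be enough, as in acetylamino or benzylamino, and so which part of acetyl(benzyl)amino carries the rise over compound 2. From the compounds shown here alone, how a carboxylic acid on the same saturated chain carbon would stand also remains open.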